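The source may report more compounds than this note shows. Statements on the series, on what has been measured and on what is new or still open speak of the compounds shown alone.

In an assay on IMR-32 cells for displacement of a labelled ligand from corticotropin-releasing factor receptor 1 (Homo sapiens), read by scintillation counting, with a stated time of 2 h (on this read-out lower numbers stand for stronger inhibition and higher numbers for weaker inhibition), three closely related compounds have been measured. Compound 1 `CCc1nc(NC(CC)CC)c(OC)nc1-c1ccc(OC(F)F)cc1Cl` gives 1.4 nM. Compound 2 `CCc1nc(NC(CC)CC)c(OC)nc1-c1ccc(Cl)cc1Cl` gives 5.9 nM, and compound 3 `CCc1nc(-c2ccc(Cl)cc2Cl)c(CC)nc1NC(CC)CC` gives 4.1 nM. Compound 2 therefore holds the highest number of the three: its gap to compound 3 lies within the usual scatter, so the two cannot be told apart, while its gap to compound 1 is larger, as the change a 4.2-fold higher number from compound 1 to compound 2 (0.62 log units; beyond the scatter) shows. The other measured step, a 1.4-fold lower number from compound 2 to compound 3 (0.16 log units; within the scatter), stays within the scatter.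

Compound 4 `CCC(CC)Nc1nc(C)c(-c2ccc(Cl)cc2Cl)nc1OC` is not yet measured. It differs from compound 2 by hydrogen in place of methyl on a saturated chain carbon bound to an aromatic carbon; seen one bond further out, an ethyl group on the core becomes a methyl group. Neither measured step is this exact change. The nearest guide is the step from compound 2 to compound 3, where a small group on the same core was swapped without any movement beyond the scatter; the larger step from compound 1 to compound 2 concerns a group on the attached ring and bears less on it. A small change in this assay is therefore expected, or none beyond the scatter, as a 1.4-fold higher number from compound 2 to compound 4 (0.13 log units; within the scatter). The estimate for compound 4 is 8 nM, with a range from 3 nM to 22 nM.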

Compound 4, inhibition constant: 4.3 nM
The estimate for compound 4 lay 1.9-fold (0.27 log units) above the measured number; the range from low to high includes it.
By their numbers in this assay, from the lowest: compound 1; then compounds 3, 4 and 2 (each within the scatter of the next).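

Cutting the ethyl group on the shared core back to a methyl group, which is hydrogen in place of methyl on a saturated chain carbon bound to an aromatic carbon, gives a 1.4-fold lower number from compound 2 to compound 4 (0.14 log units; within the scatter) in this assay and so leaves the reading unchanged within the usual noise. Going by these compounds alone, the earlier steps changed other places, so this is the first sign that this group can lose a carbon without a change that can be told from the scatter, at least in the setting of compound 2, which carries chloro on the attached ring. Nothing measured here offers a reason why the number holds when the chain is shortened.

The compounds shown span only methyl and ethyl at this place, so it remains open whether a longer chain such as propyl or butyl, or a group of another kind such as an amine or a carboxylic acid, would still leave the number in the same range. They also leave open whether shortening ethyl to methyl would behave the same way with the difluoromethoxy group of compound 1 on the attached ring.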